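The source may report more compounds than this note shows. Statements on the series, on what has been measured and on what is new or still open speak of the compounds shown alone.

In a functional assay on HT-29 cells (Homo sapiens) for cytotoxicity, read by MTT assay, with a stated time of 24 h, tested at 0.64 ug/mL (on this read-out higher numbers stand for a stronger effect at the one concentration tested and lower numbers for a weaker effect), the three measured compounds gave these numbers:

Compound 1 `Cn1c(-c2ccc(NC(=O)CCl)cc2)nc(-c2ccccc2)c1-c1ccccc1` gives 7.2%.
Compound 2 `Cn1c(-c2ccc(NC(=O)CSc3nc4ccccc4o3)cc2)nc(-c2ccccc2)c1-c1ccccc1` gives 24.8%.
Compound 3 `Cn1c(-c2ccc(NC(=O)CSC3=NCCS3)cc2)nc(-c2ccccc2)c1-c1ccccc1` gives 16.8%.

Compound 3 stands second highest of the three. Its nearest neighbour is compound 2, and the step of a number 8 percentage points lower from compound 2 to compound 3 (within the scatter) lies within the scatter; its furthest is compound 1, and the step of a number 9.6 percentage points higher from compound 1 to compound 3 (within the scatter) also lies within the scatter.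

Compound 4 `Cn1c(-c2ccc(NC(=O)CN3CCN(c4ccccc4)CC3)cc2)nc(-c2ccccc2)c1-c1ccccc1` is not yet measured. It differs from compound 3 in one place: a group of 12 heavy atoms (10 carbon, 2 nitrogen; one six-membered non-aromatic ring with 2 hetero atoms, one six-membered aromatic ring of carbon only) in place of a group of 6 heavy atoms (3 carbon, 1 nitrogen, 2 sulfur; one five-membered non-aromatic ring with 2 hetero atoms), on a saturated chain carbon bound to a carbonyl carbon.

All three measured steps alter the group on this same saturated chain carbon. Only a number 17.6 percentage points higher from compound 1 to compound 2 (beyond the scatter) was beyond the scatter, and it was modest; the other two stayed within it. On this evidence, exchanging the group at this position has moved the read-out only a little, so for compound 4 a change of about a number 3.2 percentage points higher from compound 3 to compound 4 (within the scatter) is expected, that is, none beyond the scatter. Compound 4 is therefore estimated at 20%, with a range from 6% to 38%.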

Compound 4, a percentage reported as activity, at one concentration (the size of the read-out at that concentration, not a potency): 17.3%
The estimate for compound 4 lay 2.7 percentage points above the measured number, and the stated range covers the measured number.
By their numbers in this assay, from the lowest: compounds 1, 3, 4 and 2 (each within the scatter of the next, the first and the last beyond it).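

In this assay, 4-phenylpiperazin-1-yl on the saturated chain carbon bound to a carbonyl carbon, a group without sulfur, cannot be told apart from either sulfur-bearing group, with a number 0.5 percentage points higher from compound 3 to compound 4 (within the scatter) and a number 7.5 percentage points lower from compound 2 to compound 4 (within the scatter) as the two steps. Set against chloro, the same group gives a number 10.1 percentage points higher from compound 1 to compound 4 (beyond the scatter) as its step, so a second replacement now clears the scatter from compound 1, if only modestly, while compound 3 goes against this pattern with a number 9.6 percentage points higher from compound 1 to compound 3 (within the scatter) as its step. No evidence is available on what lies behind these numbers.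

On these data alone, whether a small amine such as morpholine or a carboxylic acid on this carbon would read differently stays open. So does the part played by the phenyl ring, which a piperazine lacking that ring would test, and the single concentration gives no potency for any compound.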